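Quinoline sulfone series: cyano to fluoro, rat microsomal clearance

The source may hold more compounds than are shown below. What is called first, only, known or untested is meant among the compounds shown, and "the series" means these compounds.

Measured so far:
- compound 1, `O=S(=O)(c1ccc(F)c(Cl)c1)c1cnc2cc(F)ccc2c1-c1ccc(Cl)cc1`: 0.45 mL/min
- compound 2, `N#Cc1ccc2c(-c3ccc(Cl)cc3)c(S(=O)(=O)c3ccc(F)cc3)cnc2c1`: 0.01 mL/min

Both were run in an ADME assay on microsomes from liver (Rattus norvegicus) for metabolic stability, tested at 2.5 uM; a higher number here means faster removal of the compound, a lower number slower removal. Compound 1 gives 0.45 mL/min; compound 2 gives 0.01 mL/min. For the measured compounds named here, on these two numbers compound 2 stands lowest, with compound 1 the only neighbour, a gap that lies well beyond the usual scatter. The two compounds differ in more than one place, so that gap is not tied to any single change.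

Compound 3, `O=S(=O)(c1ccc(F)cc1)c1cnc2cc(F)ccc2c1-c1ccc(Cl)cc1`, has not yet been measured. It differs from compound 2 in one place: fluoro in place of cyano on an aromatic carbon. The remainder of the molecule, including the fluorophenyl sulfone and the chlorophenyl group, is kept as in compound 2.

Compound 1 carries the same fluoro at this position and gives 0.45 mL/min, while compound 2 with the cyano gives 0.01 mL/min; compound 1 also differs elsewhere, so only part of that gap can be credited to the fluoro. A step upward is expected, of moderate size, from compound 2 to compound 3 as a 15-fold higher number from compound 2 to compound 3 (1.18 log units; beyond the scatter). Compound 3 is estimated in this assay at 0.15 mL/min, within 0.04 mL/min to 0.5 mL/min.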

Compound 3, intrinsic clearance in a liver preparation (reported as CLH), per the amount of preparation that the assay uses: 0.89 mL/min
Beside the measured number, compound 3's estimate is 5.9-fold (0.77 log units) below it; the whole stated range lies below it.
By their numbers in this assay, from the lowest: compound 2; then compounds 1 and 3 (each within the scatter of the next).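

In this assay the change of fluoro in place of cyano on this aromatic carbon can now be read on its own: the step is an 89-fold higher number from compound 2 to compound 3 (1.95 log units; beyond the scatter) and is large, whereas the earlier pair differed in more than one place and could not isolate it. With the fluoro held, hydrogen in place of chloro on an aromatic carbon gives a 2.0-fold higher number from compound 1 to compound 3 (0.30 log units; within the scatter) and stays within the scatter, so this second change shows no readable effect on the number. Of the two single changes now available, only the exchange of cyano for fluoro moves the read-out beyond the scatter, although this rests on one pair of compounds.

No measurement shown here accounts for the size of the step at this position. From the compounds shown here alone, it remains open whether other groups on this aromatic carbon, such as an amine, a carboxylic acid or a methoxy group, would give numbers close to compound 2 or close to compound 3, and whether the exchange of chloro for hydrogen would remain within the scatter with the cyano in place.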